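The source may report more compounds than this note shows. Statements on the series, on what has been measured and on what is new or still open speak of the compounds shown alone.

Three related carboxylic acids set the scene here. In a physicochemical assay for lipophilicity, using the shake flask method, in phosphate buffer, measured as octanol-water partition, with a stated time of 24 h, at pH 7.4, tested at 100 uM (a lower number here means a more polar compound, a higher number a more lipophilic compound), compound 3 `O=C(O)CS(=O)(=O)c1ccc(OCc2cccc(-c3ccccc3)c2)cc1` gives 2.13, the lower of the two numbers available. For the measured compounds named here, the only other number belongs to compound 2 `Cc1cc(OCC2CC2)cc(C)c1-c1cccc(COc2ccc(S(=O)(=O)CC(=O)O)cc2)c1`, which gives 3.46. That places compound 2 higher than compound 3, by more than the scatter seen between repeated measurements. The third relative offers no comparison, since compound 1 `COc1cc(C)c(-c2cccc(COc3ccc4c(c3)SCC4CC(=O)O)c2)c(C)c1` has the entry "not determined" (no result reported).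

The next compound to be tested is compound 4 `O=C(O)CS(=O)(=O)c1ccc(OCc2cccc(-c3ccccc3C(F)(F)F)c2)cc1`. It differs from compound 3 by trifluoromethyl in place of hydrogen on an aromatic carbon, ortho to a large group, so that phenyl becomes 2-(trifluoromethyl)phenyl.

Going by the values given here, no two measured compounds differ in a single place, so no measured step can serve as a direct guide, and the forecast rests on the nature of this change. The few numbers in hand also give a loose upper reference, as compound 2 at 3.46 shows how far up this small set reaches. An upward move is expected, estimated as a number 0.57 log units higher from compound 3 to compound 4 (beyond the scatter), which would lie beyond the scatter. For compound 4, the expected value is 2.7, with an estimated range from 2.3 to 3.1.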

Compound 4, distribution coefficient: 2.95
Compound 4: middle estimate off by 0.25 log units, on the low side; low and high end bracket the measured number.
By their numbers in this assay, from the lowest: compound 3; then compound 4; then compound 2.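

In this assay, putting trifluoromethyl in place of hydrogen on an aromatic carbon, ortho to a large group, so that phenyl becomes 2-(trifluoromethyl)phenyl, gives a number 0.82 log units higher from compound 3 to compound 4 (beyond the scatter) and thus a clear rise in the read-out. For the compounds shown here, this is the first measured pair in the set that differs in one place only, so it offers the first direct reading of what a single change at this position does to the number; the earlier compounds differ from one another in more than one place and could not show that. No measurement among these compounds accounts for the size or direction of this step.

A chlorine atom, a nitrile or an amine on the same carbon would show whether this rise is particular to trifluoromethyl or also appears with other groups at this position. Trifluoromethyl on a different carbon of the same ring remains an open comparison too, so this single step shows what happens at one position and does not yet establish a pattern.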